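The source may report more compounds than this note shows. Statements on the series, on what has been measured and on what is new or still open speak of the compounds shown alone.

Of the compounds shown here, three built on one shared core have been tested in an assay on isolated protein (Oryctolagus cuniculus) for inhibition of Trypsin (Homo sapiens); a higher number here means a weaker inhibitor, a lower number a stronger inhibitor. Compound 3 `CCOc1ccccc1-c1ccc(C(=O)NC(/C=C/c2ccccc2)C(Cc2cccc(C(=N)N)c2)C(=O)OC)cc1` gives 1800 nM. Compound 1 `CCc1cccc(-c2ccc(C(=O)NC(/C=C/c3ccccc3)C(Cc3cccc(C(=N)N)c3)C(=O)OC)cc2)c1` gives 2600 nM, and compound 2 `COC(=O)C(Cc1cccc(C(=N)N)c1)C(/C=C/c1ccccc1)NC(=O)c1ccc(-c2ccc(OC)cc2)cc1` gives 2900 nM. Among the three numbers the one for compound 3 is the lowest, yet the distances to the other two, a 1.4-fold lower number from compound 1 to compound 3 (0.16 log units; within the scatter) and a 1.6-fold lower number from compound 2 to compound 3 (0.21 log units; within the scatter), both sit within the scatter, so no ranking can be read from them. The three differ only in the group attached at one aromatic carbon of the core, and the remaining swap there, a 1.1-fold higher number from compound 1 to compound 2 (0.05 log units; within the scatter), likewise moved the number by less than the scatter.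

Compound 4 `CCOc1cccc(-c2ccc(C(=O)NC(/C=C/c3ccccc3)C(Cc3cccc(C(=N)N)c3)C(=O)OC)cc2)c1` differs from compound 3 by 3-ethoxyphenyl in place of 2-ethoxyphenyl on an aromatic carbon. The two share the same atoms, joined differently. Every swap of this kind measured so far stayed within the scatter, so for compound 4 no step beyond it is expected either, and a 1.2-fold higher number from compound 3 to compound 4 (0.09 log units; within the scatter) is the expected outcome. Compound 4 is therefore estimated at 2200 nM, with a range from 1000 nM to 4800 nM.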

Compound 4, half-maximal inhibitory concentration: 3600 nM
Beside the measured number, compound 4's estimate is 1.6-fold (0.21 log units) below it; the measured number falls inside the stated range.
By their numbers in this assay, from the lowest: compounds 3, 1, 2 and 4 (each within the scatter of the next).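

Swapping 2-ethoxyphenyl for 3-ethoxyphenyl, which keeps the same atoms but joins them differently, gives the largest step seen at this position so far in this assay: a 2.0-fold higher number from compound 3 to compound 4 (0.30 log units; within the scatter). The other two new steps are smaller, a 1.2-fold higher number from compound 2 to compound 4 (0.09 log units; within the scatter) and a 1.4-fold higher number from compound 1 to compound 4 (0.14 log units; within the scatter), so this position has now taken ethyl, methoxy and ethoxy groups on the outer phenyl ring with every step remaining within the scatter. Nothing available accounts for the size of any of these steps.

On these data alone, all four groups are phenyl rings carrying ethyl, methoxy or ethoxy, so the effect of an amine, a carboxylic acid or a longer chain such as butoxy on that ring remains open. Also open, as far as these compounds go, is whether any group at this position can move the number beyond the scatter.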